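Hexokinase-3 inhibition by iodoacetamide-linked nucleotide analogues

The compounds below may be only part of what the source reports. "The series", "measured", "known", "first", "only" and "open" are said of these compounds alone.

Measured compounds:
compound 1 `O=C(CI)NCCCCC(=O)NCCCCCCNc1ncnc2c1ncn2[C@@H]1O[C@H](COP(=O)(O)OP(=O)(O)OP(=O)(O)O)[C@@H](O)[C@H]1O`: 0%
compound 2 `O=C(CI)NCCCCCCCCNc1ncnc2c1ncn2[C@@H]1O[C@H](COP(=O)(O)OP(=O)(O)OP(=O)(O)O)[C@@H](O)[C@H]1O`: 47%
compound 3 `O=C(CI)NCCCCCCC(=O)NCCCCCCNc1ncnc2c1ncn2[C@@H]1O[C@H](COP(=O)(O)OP(=O)(O)OP(=O)(O)O)[C@@H](O)[C@H]1O`: 0%

In an assay on isolated protein for inhibition of hexokinase-3 (Rattus norvegicus), with a stated time of 6 h, tested at 10 mM (on this read-out higher numbers stand for more inhibition at the one concentration tested (going by the name of the read-out) and lower numbers for less inhibition), compound 3 stands level with compound 1 at the digits shown, the two together the lowest of the three numbers, while compound 2 lies well above both. Going by the values given here, the only large step in the set is a number 47 percentage points higher from compound 1 to compound 2 (beyond the scatter), a shortening of the linker toward the iodoacetamide end. Lengthening in the other direction gave no change at the digits printed from compound 1 to compound 3 (within the scatter).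

Compound 4 `O=C(I)NCC(=O)NCCCCCCNc1ncnc2c1ncn2[C@@H]1O[C@H](COP(=O)(O)OP(=O)(O)OP(=O)(O)O)[C@@H](O)[C@H]1O` differs from compound 3 by a group of 4 heavy atoms (1 carbon, 1 nitrogen, 1 oxygen, 1 iodine; no ring) in place of a group of 10 heavy atoms (7 carbon, 1 nitrogen, 1 oxygen, 1 iodine; no ring), on a saturated chain carbon bound to a carbonyl carbon. This is again a shortening, so the step of a number 47 percentage points higher from compound 1 to compound 2 (beyond the scatter) bears on it, though the new group is not that of compound 2, so the outcome is uncertain. A moderate rise, a number 15 percentage points higher from compound 3 to compound 4 (beyond the scatter), is expected.

For compound 4 in this assay the estimate is 15%, with a range from 0% to 45%.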

Compound 4, a percentage reported as inhibition, at one concentration (the size of the read-out at that concentration, not a potency): 0%
For compound 4 the middle estimate is 15 percentage points above the measured one, within the range that was stated.
By their numbers in this assay, from the lowest: compounds 1, 3 and 4 (each within the scatter of the next); then compound 2.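

Shortening the chain at this position does not raise the read-out when the chain amide stays: the step is no change at the digits printed from compound 3 to compound 4 (within the scatter), and likewise no change at the digits printed from compound 1 to compound 4 (within the scatter). Length alone therefore does not recover the inhibition of compound 2, as a number 47 percentage points lower from compound 2 to compound 4 (beyond the scatter) shows, and compound 2 remains the only compound of the four with an all-carbon chain and the only one clearly above the others. No measurement on hand explains this difference.

On these data alone, it remains open whether a shorter or longer all-carbon chain would keep the inhibition. Also open, as far as these compounds go, is whether a chloroacetamide in place of the iodoacetamide would do so.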